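Aryl group swap from compound 1 to compound 4

The source may hold more compounds than are shown below. What is called first, only, known or untested is meant among the compounds shown, and "the series" means these compounds.

Measured in a functional assay on HCT-116 cells (Homo sapiens) for inhibition, read by sulforhodamine B assay, with a stated time of 48 h, tested at 50 uM; on this read-out higher numbers stand for more inhibition of growth at the one concentration tested and lower numbers for less inhibition of growth:
compound 1 `COc1ccc([C@@H]2C/C(=N/OCc3cn(-c4ccc(Cl)cc4C)nn3)c3cc(CC=C(C)C)c(OC)cc3O2)cc1` gives 20%
compound 2 `COc1cc2c(cc1CC=C(C)C)/C(=N/NC(N)=O)C[C@@H](c1ccc(O)cc1)O2` gives 87%
compound 3 `COc1cc2c(cc1CC=C(C)C)/C(=N/O)C[C@@H](c1ccc(O)cc1)O2` gives 99%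

Compound 1 stands lowest of the three, well under compound 2 and compound 3. Compound 4 `COc1ccc([C@@H]2C/C(=N/OCc3cn(-c4ccc(NC(C)=O)cc4)nn3)c3cc(CC=C(C)C)c(OC)cc3O2)cc1` is the next case: 4-acetamidophenyl in place of 4-chloro-2-methylphenyl on an aromatic nitrogen. Going by the values given here, no measured step covers this place. The only one, a number 12 percentage points higher from compound 2 to compound 3 (beyond the scatter), is a modest change on a double-bonded nitrogen, and compounds 2 and 3 lack the five-membered aromatic ring altogether. Their high values therefore give only weak guidance. Compound 1 remains the closest reference, so only a small rise is expected in this assay, with wide uncertainty. The expected change is a number 10 percentage points higher from compound 1 to compound 4 (within the scatter). Compound 4 is estimated at 30%, with an expected range of 10% to 55%.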

Compound 4, percent growth inhibition at one concentration: 6%
Estimate against measurement, compound 4: 24 percentage points above; measured number below the stated range.
By their numbers in this assay, from the lowest: compound 4; then compound 1; then compound 2; then compound 3.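

In this assay the swap to 4-acetamidophenyl from 4-chloro-2-methylphenyl, with a change of a number 14 percentage points lower from compound 1 to compound 4 (beyond the scatter), shows that the group on this aromatic nitrogen can move the read-out. At this position, the hydrogen-bond donor and acceptor that enter with 4-acetamidophenyl bring no gain in growth inhibition. No measurement of any property bears on this step. From the compounds shown here alone, how a plain phenyl or a benzyl group on the same nitrogen would read remains open. Also open, going by these compounds, is whether the chloro or the methyl group accounts for the higher number of compound 1.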